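The compounds below may be only part of what the source reports. "The series", "measured", "known", "first", "only" and "open" are said of these compounds alone.

Measured so far:
- compound 1, `Cn1cnc2c(Sc3ccccc3)ncnc21`: 8%
- compound 2, `Cn1cnc2c(Sc3ccc(F)cc3)ncnc21`: 5%
- compound 3, `Cn1c(-c2ccccc2)nc2c(Sc3ccc(F)cc3)ncnc21`: 8%

All three were tested in an assay on isolated protein for inhibition of Ca2+/calmodulin-dependent protein kinase II (CaM kinase II) (Rattus norvegicus), tested at 30 uM; a lower number here means less inhibition, a higher number more inhibition at the concentration tested (going by the name of the read-out). Compound 2 gives the lowest of the three numbers, but its nearest neighbour is compound 1 with 8% and the furthest is compound 3 with 8%, and both gaps lie within the scatter, so the three compounds cannot be told apart on these data.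

The next compound is compound 4, `Fc1ccc(Cn2cnc3c(Sc4ccc(F)cc4)ncnc32)cc1`. Compared with compound 2 the change is 4-fluorophenyl in place of hydrogen on a saturated chain carbon bound to an aromatic nitrogen. Cut one bond further out, the same change reads: methyl to 4-fluorobenzyl.

For the measured compounds named here, two measured steps bear on it. Adding a fluorine gave a number 3 percentage points lower from compound 1 to compound 2 (within the scatter), and adding a phenyl gave a number 3 percentage points higher from compound 2 to compound 3 (within the scatter), both small. Going by the values given here, neither step adds a ring on the saturated chain carbon, so this exact change has no direct precedent; still, every change seen so far left the number where it was, and a 4-fluorophenyl entering at a new place is expected to do the same.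

The expected step is therefore a number 2 percentage points higher from compound 2 to compound 4 (within the scatter), within the scatter, and compound 4 is estimated at 7%, in the range -5% to 20%.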

Compound 4, a percentage reported as inhibition, at one concentration (the size of the read-out at that concentration, not a potency): 0%
Compound 4: middle estimate off by 7 percentage points, on the high side, within the range that was stated.
By their numbers in this assay, from the lowest: compounds 4, 2, 1 and 3 (each within the scatter of the next).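

In this assay the change from methyl to 4-fluorobenzyl gives a number 5 percentage points lower from compound 2 to compound 4 (within the scatter) and so shows that a 4-fluorophenyl of 7 heavy atoms can sit on the saturated chain carbon bound to an aromatic nitrogen without the number leaving the usual scatter. The earlier steps shown here were made at other places on the molecule, so this is a third place where a change leaves the compounds impossible to tell apart, and adding a whole ring here brings no measurable gain in inhibition at the concentration tested. No separate measurement is available that could explain this result.

The compounds shown leave open whether this place responds to anything other than a 4-fluorobenzyl, such as a longer chain ending in an amine or a carboxylic acid. They also leave open which change to the shared core, if any, would lift the number in this assay clearly beyond the scatter.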